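Compound 1 at the Limit, a Seven-Atom Group Enters

A few compounds are considered here, and "the series" means these few. Any claim that something is new, unique, unknown or untested is made for them only; others in the source may bear on it.

Measured compounds:
Compound 1 `COc1ccc(-c2nc3cc(C(C)O)ccc3[nH]2)cc1`: >= 100000 nM
Compound 2 `COc1ccc(-c2nc3cc(C(C)O)ccc3[nH]2)c(OC)c1`: >= 100000 nM

In an ADME assay on MT4 cells (Homo sapiens) for cytotoxicity, read by MTT assay, with a stated time of 96 h (a lower number here means that less compound is tolerated, a higher number that more compound is tolerated), compound 1 gives >= 100000 nM, which is a limit of the assay and not a number. In this assay compound 2 likewise gives >= 100000 nM, again a limit. Both values belong to the limit of >= 100000 nM in this assay, at which 2 of the 2 values shown sit, so compound 1 stands where every measured compound in this study stands, at the limit. Within the data shown here, the single measured step, a step that the two limits leave unreadable from compound 1 to compound 2, cannot be sized, since both of its ends are limits.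

Compound 3 `COc1ccc(-c2nc3cc(/C(C)=N/NC(N)=S)ccc3[nH]2)cc1` differs from compound 1 by a group of 7 heavy atoms (3 carbon, 3 nitrogen, 1 sulfur; no ring) in place of a group of 3 heavy atoms (2 carbon, 1 oxygen; no ring), on an aromatic carbon. Among the measured compounds shown here, no measured step involves this change, and the one step recorded gives no size for any change. For the measured compounds named here, what the numbers offer is only that compound 1 reaches the limit. Compound 3 is therefore expected to sit at or near the limit too, with a number below it possible but not suggested by anything measured. Compound 3 is expected to give 100000 nM in this assay, within 20000 nM to 100000 nM. The expected step this estimate implies is a number no higher from compound 1 to compound 3 (the limit leaves the size open), which is estimated to be small or unreadable.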

Compound 3, half-maximal cytotoxic concentration: 5000 nM
Compound 3: middle estimate off by 20-fold (1.30 log units), on the high side, outside the stated range (below it).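

Until now, the two compounds shown sat at the same limit and no change could be sized. The group of 7 heavy atoms (3 carbon, 3 nitrogen, 1 sulfur) gives the first readable movement in this assay: in place of 1-hydroxyethyl, it produces an at least 20-fold lower number from compound 1 to compound 3 (1.30 log units; beyond the scatter). This shows that what stands on this aromatic carbon of the fused system can decide how much compound the cells tolerate, which the methoxy change on the other ring could not show, since both ends of that step are limits. Compound 1 remains at a limit, so the true gap may be wider than the printed one: the limit of >= 100000 nM in this assay, at which 2 of the 3 values shown sit.

The entering group differs from 1-hydroxyethyl in several ways at once, including its sulfur, its added nitrogens and its double bonds, so the compounds shown do not say which part carries the step. Going by these compounds, a plain acetyl group, or the same chain with a carbonyl oxygen in place of the sulfur, would separate these parts, and whether a second methoxy on the other ring alters the step also remains open.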